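From Cyclohexyl to Methyl: Expecting Weaker Inhibition

The source may report more compounds than this note shows. Statements on the series, on what has been measured and on what is new or still open speak of the compounds shown alone.

Within the data shown here, compound 1 `O[C@@H]1[C@@H](OCc2ccccc2)[C@H](OCc2ccccc2)[C@@H](COCc2ccccc2)O[C@H]1CC1CCCCC1` gives 4100 nM in a functional assay on HL-60 cells (Homo sapiens) for antiproliferative activity, read by MTT assay (on this read-out lower numbers stand for stronger inhibition and higher numbers for weaker inhibition), and is the only compound with a number. Compound 2 `CC(=O)OC[C@@H]1O[C@H](COCc2ccccc2)[C@@H](OCc2ccccc2)[C@H](OCc2ccccc2)[C@H]1OCc1ccccc1` is reported in this assay as "not active" (no number reported), without a number. Compound 3 `CC[C@@H]1O[C@H](COCc2ccccc2)[C@@H](OCc2ccccc2)[C@H](OCc2ccccc2)[C@H]1O` has not yet been measured; it differs from compound 1 by methyl in place of cyclohexyl on a saturated chain carbon bound to a saturated ring carbon. Among the measured compounds shown here, no measured pair shows a change of this kind, so the size of the step can only be estimated. The expectation is a weakening beyond the usual scatter, an estimated step of a 2.9-fold higher number from compound 1 to compound 3 (0.47 log units; beyond the scatter). For compound 3 the estimated value in this assay is 12000 nM, with a range from 4000 nM to 40000 nM.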

Compound 3, half-maximal inhibitory concentration: 8200 nM
Compound 3: middle estimate off by 1.5-fold (0.17 log units), on the high side, and the stated range covers the measured number.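

In this assay, methyl in place of cyclohexyl on a saturated chain carbon bound to a saturated ring carbon gives a 2.0-fold higher number from compound 1 to compound 3 (0.30 log units; within the scatter) and so the two compounds cannot be told apart. At this position, then, the six-membered carbon ring is not needed for a measurable number in this cell assay. No supporting data bear on why the read-out behaves this way. From the compounds shown here alone, only these two groups can be compared at this position, so it remains open how a longer chain, an amine or a carboxylic acid there would read.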